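A Ring Replaces the Side Chain of Compound 2

The source may report more compounds than this note shows. Statements on the series, on what has been measured and on what is new or still open speak of the compounds shown alone.

In an ADME assay on the whole organism (strain CD1) for metabolic stability, with Mus musculus as the target, read by LC-MS, at a dose of 5 mg/kg by the oral route (on this read-out higher numbers stand for a longer-lived compound and lower numbers for a shorter-lived compound), compound 1 `Cc1c(Oc2cnc(C(=O)NCCO)cn2)ccc2c1B(O)OC2` gives 3 h. Compound 2 `Cc1c(Oc2cnc(C(=O)NC(C)CO)cn2)ccc2c1B(O)OC2` gives 2.7 h, and compound 3 `Cc1c(Oc2cnc(C(=O)N[C@@H](CO)CC(F)(F)F)cn2)ccc2c1B(O)OC2` gives 3 h, so compound 2 stands level with the other two, all within the usual scatter.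

Compound 4 `Cc1c(Oc2cnc(C(=O)N3CC(C)(O)C3)cn2)ccc2c1B(O)OC2` has not yet been measured. It differs from compound 2 in one place, on a carbonyl carbon: 3-hydroxy-3-methylazetidin-1-yl in place of (1-(hydroxymethyl)ethyl)amino on a carbonyl carbon.

For the measured compounds named here, three measured steps bear on this change, all of them between open chains: a 1.1-fold lower number from compound 1 to compound 2 (0.05 log units; within the scatter), no change at the digits printed from compound 1 to compound 3 (within the scatter) and a 1.1-fold higher number from compound 2 to compound 3 (0.05 log units; within the scatter). Each is within the scatter. None of them introduces a ring or removes the amide hydrogen, so they are only indirect guides and the range must stay wide.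

No step beyond the scatter is expected, and the estimated size is a 1.1-fold higher number from compound 2 to compound 4 (0.05 log units; within the scatter). Compound 4 is estimated at 3 h, with an expected range from 1.5 h to 6 h.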

Compound 4, half-life: 6.8 h
Estimate against measurement, compound 4: 2.3-fold (0.36 log units) below; measured number above the stated range.
By their numbers in this assay, from the lowest: compounds 2, 1 and 3 (each within the scatter of the next); then compound 4.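

In this assay, the open chains on the amide-type nitrogen did not separate from one another, but a ring at this place on the carbonyl carbon does: 3-hydroxy-3-methylazetidin-1-yl gives a 2.5-fold higher number from compound 2 to compound 4 (0.40 log units; beyond the scatter) and a 2.3-fold higher number from compound 3 to compound 4 (0.36 log units; beyond the scatter) as well as a 2.3-fold higher number from compound 1 to compound 4 (0.36 log units; beyond the scatter) in the same direction. For the compounds shown here, this is the first change in the set to step beyond the scatter, and it does so against all three open-chain compounds, though each step is modest. No measurement shown here explains the longer half-life.

In compound 4 the four-membered ring, the methyl on it and the loss of the amide hydrogen all arrive together, so the compounds shown do not separate their contributions. On these data alone, how a five-membered pyrrolidine ring, or an azetidine carrying an amine in place of the hydroxyl, would behave also remains open.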